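Changing the amide aryl group: tolerated concentration

A few compounds are considered here, and "the series" means these few. Any claim that something is new, unique, unknown or untested is made for them only; others in the source may bear on it.

In an ADME assay on MT4 cells (Homo sapiens) for cytotoxicity, read by MTT assay (a lower number here means that less compound is tolerated, a higher number that more compound is tolerated), compound 1 `Cc1ccc(NC(=O)CSc2nncnc2-c2cccc3ccccc23)c(Br)c1` gives 166000 nM and compound 2 `COC(=O)c1ccc(NC(=O)CSc2nncnc2-c2cccc3ccccc23)c(Br)c1` gives 173000 nM, so the two lie within the scatter of each other. Compound 3 `Cc1ccccc1NC(=O)CSc1nncnc1-c1cccc2ccccc12` differs from compound 1 as follows: 2-methylphenyl in place of 2-bromo-4-methylphenyl on an amide-type nitrogen. Going by the values given here, the one measured step, a 1.0-fold higher number from compound 1 to compound 2 (0.02 log units; within the scatter), is a different exchange on the same aryl group, and no measured step covers this one. It offers only weak support for a flat response in this assay. The estimated step of a 1.1-fold lower number from compound 1 to compound 3 (0.04 log units; within the scatter) is expected to stay within the scatter. Compound 3 is expected at 150000 nM, with an estimated range of 70000 nM to 300000 nM.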

Compound 3, half-maximal cytotoxic concentration: 158000 nM
The estimate for compound 3 lay 1.1-fold (0.02 log units) below the measured number; the range from low to high includes it.
By their numbers in this assay, from the lowest: compounds 3, 1 and 2 (each within the scatter of the next).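

In this assay, the flat response now extends beyond a single exchange on the aryl group: 2-methylphenyl in place of 2-bromo-4-methylphenyl gives a 1.1-fold lower number from compound 1 to compound 3 (0.02 log units; within the scatter). The earlier pair, compound 1 and compound 2, both carry the bromine, whereas compound 3 shows that an aryl group without it also stays within the scatter. Nothing measured here speaks to why these numbers stay level.

Still open, on these data alone, is whether an amine or a carboxylic acid on this aryl ring would leave the number level. Also open, as far as these compounds go, is whether a longer alkyl chain in place of the aryl group on the amide nitrogen would do so.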